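This account rests on a few compounds, and the source may have more. Where it says the series, first, only, none or still open, it means among the compounds named here.

Measured so far:
compound 1, `COc1ccc(-c2cc(/C=C/C(=O)c3cc(OC)c(OC)c(OC)c3)[nH]n2)cc1OC` — 22100 nM
compound 2, `COc1ccc(-c2cc(/C=C/C(=O)c3ccc(N)cc3)[nH]n2)cc1` — 24400 nM

Both numbers come from a functional assay on Hs-578T cells (Homo sapiens) for inhibition, read by sulforhodamine B assay, with a stated time of 48 h; a higher number here means a weaker inhibitor of growth, a lower number a stronger inhibitor of growth. Compound 1 gives 22100 nM, and compound 2 gives 24400 nM. The two values lie within the usual scatter of repeated measurements, so compound 1 stands level with compound 2 on the numbers shown, and nothing separates them. Going by the values given here, the two measured compounds differ in more than one place, so no single-point step between measured compounds is available, and the series gives no calibration for the change considered below.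

Compound 3, `COc1cc(C(=O)/C=C/c2cc(-c3cc(OC)c(OC)c(OC)c3)n[nH]2)cc(OC)c1OC`, is to be measured in this assay. It differs from compound 1 in one place: methoxy in place of hydrogen on an aromatic carbon. The rest of the structure, the enone link and the shared core, is unchanged. Among the compounds with values here, with no measured step to lean on, the step from compound 1 to compound 3 is expected to be small, with no direction beyond the scatter, and is estimated as a 1.1-fold lower number from compound 1 to compound 3 (0.04 log units; within the scatter). On that basis compound 3 is expected to give about 20000 nM, with a range from 8000 nM to 50000 nM.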

Compound 3, concentration for total growth inhibition: 53900 nM
Beside the measured number, compound 3's estimate is 2.7-fold (0.43 log units) below it; measured number above the stated range.
By their numbers in this assay, from the lowest: compounds 1 and 2 (each within the scatter of the next); then compound 3.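

In this assay, methoxy in place of hydrogen on an aromatic carbon, ortho to a methoxy group and meta to both a large group and a second methoxy group, gives a 2.4-fold higher number from compound 1 to compound 3 (0.39 log units; beyond the scatter) and so marks a weaker inhibitor of growth. Going by these compounds alone, this is the first single-point step, and it shows that this position does not take the added methoxy without a modest loss, something compound 1 and compound 2 could not show when compared only with each other. Nothing available bears on the reason for this loss.

As far as these compounds go, whether the loss belongs to methoxy itself or would also come with another group at this position stays open, for instance a hydroxy group, a fluorine atom or an amine. Also open, from the compounds shown here alone, is whether the same change would give a step of similar size and direction on a different parent compound, as this reading rests on a single pair in a single assay.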